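The compounds below may be only part of what the source reports. "The series", "measured", "known", "first", "only" and "open" are said of these compounds alone.

Compound 1 `c1csc(-c2cc(-c3ccncc3)nc(-c3ccsc3)c2)c1` is the weakest of the three measured compounds in a functional assay on SK-MEL-2 cells (Homo sapiens) for cytotoxicity, read by sulforhodamine B assay, with a stated time of 48 h (on this read-out higher numbers stand for weaker inhibition and lower numbers for stronger inhibition), where compound 1 gives 8940 nM. Compound 2 `c1csc(-c2cc(-c3ccncc3)nc(-c3cccs3)c2)c1` gives 3680 nM, and the step of a 2.4-fold lower number from compound 1 to compound 2 (0.39 log units; beyond the scatter) is the only one here that lies beyond the scatter. Compound 3 `c1cncc(-c2cc(-c3ccsc3)cc(-c3cccs3)n2)c1` gives 5610 nM, a number that sits within the scatter of compound 1.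

Compound 4 `c1coc(-c2cc(-c3ccncc3)nc(-c3ccsc3)c2)c1` differs from compound 1 by furan-2-yl in place of thiophen-2-yl on an aromatic carbon. Among the measured compounds shown here, no measured step swaps one five-membered ring for another of a different hetero atom, so nothing here shows how large such a change might be. Compound 4 is therefore expected to stay close to compound 1, with a 1.1-fold higher number from compound 1 to compound 4 (0.05 log units; within the scatter) expected to lie within the scatter. The estimate for compound 4 is 10000 nM, ranging from 4500 nM to 22000 nM.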

Compound 4, half-maximal inhibitory concentration: 5430 nM
Compound 4: the middle estimate sits 1.8-fold (0.27 log units) above what was measured; measured number inside the range.
By their numbers in this assay, from the lowest: compounds 2, 4, 3 and 1 (each within the scatter of the next, the first and the last beyond it).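

Among the compounds shown here, at this position, opposite the ring nitrogen, the first change of hetero atom in the five-membered ring gives a 1.6-fold lower number from compound 1 to compound 4 (0.22 log units; within the scatter) in this assay, so oxygen in place of sulfur in that ring leaves the number within the scatter. The ring swap therefore shows no clear gain or loss in this setting. No measurement here explains this result. Still open, from the compounds shown here alone, is whether a non-aromatic group at this place, such as an amine or a carboxylic acid, would keep cytotoxicity in this range.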